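Adding one methyl to compound 1

The source may hold more compounds than are shown below. What is called first, only, known or untested is meant among the compounds shown, and "the series" means these compounds.

Within the data shown here, in a functional assay (CEM-VLB cells, Homo sapiens) for antiproliferative activity, read by sulforhodamine B assay, with a stated time of 48 h (a lower number here means a stronger inhibitor, a higher number a weaker inhibitor), compound 1 `Cc1cccc(NS(=O)(=O)c2ccc(N3CCNC3=O)cc2)c1` gives 370 nM, the only actual number so far. Compound 2 `COc1cc(NS(=O)(=O)c2ccc(N3CCNC3=O)cc2)cc(OC)c1OC` gives > 250 nM, which is a limit and not a number. Compound 3 `Cc1cc(C)cc(NS(=O)(=O)c2ccc(N3CCNC3=O)cc2)c1` keeps the core of compound 1 and differs in one place: methyl in place of hydrogen on an aromatic carbon, so that 3-methylphenyl becomes 3,5-dimethylphenyl. Among the measured compounds shown here, no measured step bears on this change, and no shift beyond the scatter is expected in this assay. The estimated step is a 1.2-fold lower number from compound 1 to compound 3 (0.09 log units; within the scatter). For compound 3 the expected value is 300 nM, with an estimated range from 100 nM to 900 nM.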

Compound 3, half-maximal inhibitory concentration: 400 nM
Compound 3: middle estimate off by 1.3-fold (0.12 log units), on the low side; the measured number falls inside the stated range.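

Among these compounds, the step to 3,5-dimethylphenyl is the first measured step: a 1.1-fold higher number from compound 1 to compound 3 (0.03 log units; within the scatter). A methyl on this aromatic carbon, meta to a large group and meta to a methyl group, therefore brings no shift beyond the scatter. Among the compounds shown here, compound 2 stands at a limit and not at a number, so it adds no step: the limit of > 250 nM in this assay, at which 1 of the 3 values shown sits. Going by these compounds, whether an amine or a carboxylic acid at this position would shift the number stays open, as does the outcome with a longer chain in place of the methyl.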